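This account rests on a few compounds, and the source may have more. Where it says the series, first, only, none or still open, it means among the compounds named here.

Measured compounds:
Compound 1 `CC1=C(C(=O)OCc2ccccc2)C(c2ccoc2)NC(=O)N1`: 1%
Compound 2 `CC1=C(C(=O)C2CC2)C(c2ccoc2)NC(=O)N1`: 16%
Compound 3 `CCSC(=O)C1=C(C)NC(=O)NC1c1ccoc1`: 1%

Within the data shown here, in an assay on membranes from HeLa cells for displacement of a labelled ligand from adenosine receptor A3 (Homo sapiens), read by scintillation counting, with a stated time of 180 min, tested at 1 uM (on this read-out lower numbers stand for less inhibition and higher numbers for more inhibition at the one concentration tested (going by the name of the read-out)), compound 3 gives 1%, level with compound 1 at the digits printed, the two of them together the lowest of the three numbers; the only compound that stands apart is compound 2, and the step of a number 15 percentage points lower from compound 2 to compound 3 (beyond the scatter) is the one measured change beyond the scatter. Compound 4 `CC1=C(C(=O)OCC2CC2)C(c2ccoc2)NC(=O)N1` differs from compound 3 by cyclopropylmethoxy in place of ethylsulfanyl on a carbonyl carbon. The change at this carbonyl carbon resembles the measured step in that it again exchanges the group on the carbonyl carbon, but the group that enters here is not the one that left in the measured step, so that step bears on it only loosely. Compound 1, which also carries an ester-type group on the same carbonyl carbon, gives 1%, a value no different from compound 3 at the digits printed. Compound 4 is therefore expected to stay low, with a step of a number 3 percentage points higher from compound 3 to compound 4 (within the scatter) that remains within the scatter. The estimate for compound 4 in this assay is 4%, with a range from 0% to 15%.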

Compound 4, a percentage reported as inhibition, at one concentration (the size of the read-out at that concentration, not a potency): 3%
For compound 4 the middle estimate is 1 percentage points above the measured one; the range from low to high includes it.
By their numbers in this assay, from the lowest: compounds 1, 3 and 4 (each within the scatter of the next); then compound 2.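

In this assay, cyclopropylmethoxy and ethylsulfanyl on the carbonyl carbon give numbers that do not separate (a number 2 percentage points higher from compound 3 to compound 4 (within the scatter)), and neither do the cyclopropyl and phenyl ends of the ester chain (a number 2 percentage points higher from compound 1 to compound 4 (within the scatter)), so compounds 1, 3 and 4 all sit together within the scatter. Among these compounds, the cyclopropyl ring in compound 4 does not bring the number of compound 2 with it (a number 13 percentage points lower from compound 2 to compound 4 (beyond the scatter)), which shows that in this small set the ring placed directly on the carbonyl carbon, and not the same ring within cyclopropylmethoxy, goes with the one number that stands apart. No measurement offered here accounts for these numbers.

As far as these compounds go, whether an amine joined to the carbonyl carbon through its nitrogen would stand with compound 2 or with the other three stays open. The same holds for a cyclobutyl ring or a longer carbon chain on that carbon.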